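A New Ring on the Ether Oxygen

This account rests on a few compounds, and the source may have more. Where it says the series, first, only, none or still open, it means among the compounds named here.

- Compound 1 `COc1cccc(OC(c2ccc(C(F)(F)F)cc2)C2CCN(C(C)CCNC(=O)c3c(Cl)cncc3Cl)CC2)n1` gives 32700 nM
- Compound 2 `CC(CCNC(=O)c1c(Cl)cncc1Cl)N1CCC(C(Oc2cccc(Cl)n2)c2ccc(C(F)(F)F)cc2)CC1` gives > 32500 nM (a limit, not a number)

In an ADME assay on PBMC cells (Homo sapiens) for cytotoxicity (a lower number here means that less compound is tolerated, a higher number that more compound is tolerated), compound 2 stands at > 32500 nM, which is a limit and not a number.

Compound 3 `CC(CCNC(=O)c1c(Cl)cncc1Cl)N1CCC(C(Oc2ccccc2C#N)c2ccc(C(F)(F)F)cc2)CC1` carries 2-cyanophenyl in place of 6-chloropyridin-2-yl on an oxygen on a saturated carbon, a change counted as 2-cyanophenyl in place of 6-chloropyridin-2-yl on an oxygen on a saturated carbon and not yet tested.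

Going by the values given here, the only measured step, a step that the limit leaves unreadable from compound 1 to compound 2, is a different change and gives no size to carry over. Among the compounds with values here, compound 1, at 32700 nM, is the only true number available, so no step beyond the scatter is expected in this assay.

The expected step is an at least 1.0-fold lower number from compound 2 to compound 3 (0.03 log units; that floor lies within the scatter), though this rests on little evidence.

Compound 3 is estimated at 30000 nM, with an expected range from 15000 nM to 50000 nM, and the reading may again be only a limit.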

Compound 3, half-maximal cytotoxic concentration: 17000 nM
Estimate against measurement, compound 3: 1.8-fold (0.25 log units) above; low and high end bracket the measured number.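

In this assay, 2-cyanophenyl on the ether oxygen in place of 6-methoxypyridin-2-yl gives a 1.9-fold lower number from compound 1 to compound 3 (0.28 log units; within the scatter), and in place of 6-chloropyridin-2-yl it gives an at least 1.9-fold lower number from compound 2 to compound 3 (0.28 log units; that floor lies within the scatter). Going by these compounds alone, this shows that an aromatic ring of carbon only, carrying a nitrile, can sit at this position with a reading still within the scatter of compound 1, so the ring nitrogen of the earlier compounds is not needed to keep the reading there. The step from the chloro compound is only a floor because compound 2 has a limit and not a number: the limit of > 32500 nM in this assay, at which 1 of the 3 values shown sits.

As far as these compounds go, whether the nitrile and the ring nitrogen count separately stays open, as the two change together here. From the compounds shown here alone, how a plain phenyl, or a ring bearing an amine or a carboxylic acid, would read at this position also remains open.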